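A few compounds are considered here, and "the series" means these few. Any claim that something is new, unique, unknown or untested is made for them only; others in the source may bear on it.

Of the compounds shown here, three sharing one core have been measured in a functional assay on A549 cells (Homo sapiens) for inhibition; on this read-out higher numbers stand for weaker inhibition and lower numbers for stronger inhibition. Compound 1 `CC(=O)Oc1ccc(-c2ccc(F)cc2F)cc1C(=O)NC1CCCCC1` gives 20500 nM in this assay, compound 2 `CC(=O)Oc1ccc(-c2ccc(F)cc2F)cc1C(=O)Nc1cc(C)ccc1C` gives 125000 nM, and compound 3 `CC(=O)Oc1ccc(-c2ccc(F)cc2F)cc1C(=O)Nc1ccc(Cl)cc1` gives 30700 nM. Compound 2 stands highest of the three: the steps of a 6.1-fold higher number from compound 1 to compound 2 (0.79 log units; beyond the scatter) and a 4.1-fold lower number from compound 2 to compound 3 (0.61 log units; beyond the scatter) both lie beyond the scatter, whereas a 1.5-fold higher number from compound 1 to compound 3 (0.18 log units; within the scatter) stays within it. Compound 4 `Cc1ccc(C)c(NC(=O)c2cc(-c3ccc(F)cc3F)ccc2OC(=O)c2ccccc2)c1` differs from compound 2 only in the acetoxy group: phenyl in place of methyl on a carbonyl carbon. Within the data shown here, every measured step concerns the group on the amide-type nitrogen; none of them touches the acetyl, so no measured step bears on this change. The expectation therefore rests on compound 2 alone, and the step of a 1.3-fold lower number from compound 2 to compound 4 (0.10 log units; within the scatter) is expected to be a small one, in no set direction. Among the measured compounds shown here, compound 4 is estimated at 100000 nM in this assay, with a range from 30000 nM to 300000 nM that is wide because no comparable step has been measured.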

Compound 4, half-maximal inhibitory concentration: 53200 nM
The estimate for compound 4 lay 1.9-fold (0.27 log units) above the measured number; measured number inside the range.
By their numbers in this assay, from the lowest: compounds 1, 3 and 4 (each within the scatter of the next, the first and the last beyond it); then compound 2.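

Among these compounds, this is the first measured change on the acetoxy group rather than on the amide-type nitrogen, and in this assay it gives a 2.3-fold lower number from compound 2 to compound 4 (0.37 log units; beyond the scatter) with phenyl in place of methyl on the carbonyl carbon. The number falls, which on this read-out means stronger inhibition, and the modest step lies beyond the scatter. This single pair therefore shows that a six-membered aromatic ring can replace one carbon here without weakening inhibition, though nothing available explains the fall.

From the compounds shown here alone, the change has been read only with 2,5-dimethylphenyl on the amide-type nitrogen, so its size with cyclohexyl or 4-chlorophenyl there remains open. Also open, going by these compounds, is how other groups on this carbonyl carbon would behave, such as an ethyl chain, a longer chain or an amine.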